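Piperazine aryl variation on the imide series

The source may report more compounds than this note shows. Statements on the series, on what has been measured and on what is new or still open speak of the compounds shown alone.

Measured so far in a functional assay on the whole organism (strain CD-1) with Mus musculus as the target, in the maximal electroshock model, with a stated time of 2 h; on this read-out higher numbers stand for an effect only at larger amounts of compound and lower numbers for an effect already at smaller amounts:
compound 1, `CC1(c2ccccc2)CC(=O)N(CC(=O)N2CCN(c3ccccc3F)CC2)C1=O`: "not active" (no number reported)
compound 2, `CC1(c2ccccc2)CC(=O)N(CC(=O)N2CCN(c3ccc(F)cc3)CC2)C1=O`: 100 mg/kg

Among the measured compounds shown here, compound 2 carries the only number reported in this assay; compound 1 is reported in this assay only as "not active" (no number reported), without a number, and so gives no measured step against compound 2. For the measured compounds named here, the two entries together say only that the 4-fluorophenyl compound yields a number while the 2-fluorophenyl compound does not.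

Compound 3 `CC1(c2ccccc2)CC(=O)N(CC(=O)N2CCN(c3ncccn3)CC2)C1=O` is not yet measured. Relative to compound 2 the change is pyrimidin-2-yl in place of 4-fluorophenyl on an amine nitrogen in a ring. Going by the values given here, no pair of measured compounds shows this kind of exchange, so the data fix neither the size nor the direction of the step in this assay. With nothing to support a shift either way, the step from compound 2 to compound 3 is expected to stay within the scatter, estimated as no change at the digits printed from compound 2 to compound 3 (within the scatter). Compound 3 is accordingly expected to give about 100 mg/kg in this assay, with an expected range from 50 mg/kg to 300 mg/kg, and a real chance that only an inactive entry is reported, as for compound 1.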

Compound 3, minimum effective dose: "not active" (no number reported)
Compound 3: no number reported; there is nothing to compare the estimate with.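

Among the compounds shown here, compound 3, like compound 1, stands in this assay without a number, so no step from compound 2 to compound 3 can be read. No measurement shown bears on this result. The compounds shown leave open how large a shift, and in which direction, pyrimidin-2-yl in place of 4-fluorophenyl produces on this read-out.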